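Hydrazine linker and loss of bromo on a benzothiazole

This account rests on a few compounds, and the source may have more. Where it says the series, first, only, none or still open, it means among the compounds named here.

Three compounds have been measured in a physicochemical assay, read by spectrophotometry, with a stated time of 10 min; a higher number here means a weaker inhibitor, a lower number a stronger inhibitor:
compound 1 `Cc1ccc2nc(NCCCCOc3cc(O)c4c(=O)cc(-c5ccccc5)oc4c3)sc2c1` gives 8.79 ug/mL;
compound 2 `O=c1cc(-c2ccccc2)oc2cc(OCCCCNc3nc4ccc(Br)cc4s3)cc(O)c12` gives 6.57 ug/mL;
compound 3 `O=c1cc(-c2ccccc2)oc2cc(OCCCCNc3nc4ccc(C(F)(F)F)cc4s3)cc(O)c12` gives 4.95 ug/mL.

Compound 2 stands second highest of the three, with compound 3 nearest and compound 1 furthest, both within the scatter. The steps measured so far are a 1.3-fold lower number from compound 1 to compound 2 (0.13 log units; within the scatter), a 1.8-fold lower number from compound 1 to compound 3 (0.25 log units; within the scatter) and a 1.3-fold lower number from compound 2 to compound 3 (0.12 log units; within the scatter), each a swap on an aromatic carbon and none reaching beyond the scatter.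

Compound 4 `O=c1cc(-c2ccccc2)oc2cc(OCCCCNNc3nc4ccccc4s3)cc(O)c12` differs from compound 2 as follows: (1,3-benzothiazol-2-yl)amino in place of 6-bromo-1,3-benzothiazol-2-yl on an amine nitrogen. For the measured compounds named here, this change removes the bromo and lengthens the link by one nitrogen; no measured step touches either the linker or the loss of an aromatic substituent outright, so the measured steps bear on it only in that no swap at that aromatic carbon moved this assay beyond the scatter. A step beyond the scatter is therefore not expected, in either direction. Compound 4 is expected to give 8 ug/mL, ranging from 4 ug/mL to 16 ug/mL, which means an estimated step of a 1.2-fold higher number from compound 2 to compound 4 (0.09 log units; within the scatter).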

Compound 4, half-maximal inhibitory concentration: 8.73 ug/mL
Beside the measured number, compound 4's estimate is 1.1-fold (0.04 log units) below it; measured number inside the range.
By their numbers in this assay, from the lowest: compounds 3, 2, 4 and 1 (each within the scatter of the next).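

In this assay, taking out the bromo and adding a nitrogen to the link gives a 1.3-fold higher number from compound 2 to compound 4 (0.12 log units; within the scatter) while the same new group in place of 6-methyl-1,3-benzothiazol-2-yl gives a 1.0-fold lower number from compound 1 to compound 4 (0.00 log units; within the scatter) and neither step leaves the scatter. Earlier steps at this aromatic carbon only exchanged one substituent for another, whereas compound 4 shows that the number also stays within the scatter with no substituent there and a changed link on the amine nitrogen. No measurement in hand explains why these numbers stay so close.

The two parts of the change arrive together in compound 4, and the separate share of each cannot be read. The compounds shown leave open whether a carboxylic acid or an amine on that aromatic carbon, or a longer chain in the link, would move the number beyond the scatter.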